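Diethylsulfamoyl for Methoxy in a Cytotoxicity Series

The source may report more compounds than this note shows. Statements on the series, on what has been measured and on what is new or still open speak of the compounds shown alone.

Compound 1 `CS(=O)(=O)c1cccc(C(=O)N2CCCC(C(=O)Nc3ccc(Cl)cc3)C2)c1` gives 2% in an ADME assay on PC-3 cells (Homo sapiens) for cytotoxicity, read by WST assay, tested at 100 uM; on this read-out higher numbers stand for more inhibition at the one concentration tested (going by the name of the read-out) and lower numbers for less inhibition.
Compound 2 `C=Cc1cccc(C(=O)N2CCCC(C(=O)Nc3ccc(Cl)cc3)C2)c1` gives 0%.
Compound 3 `COc1cccc(C(=O)N2CCCC(C(=O)Nc3ccc(Cl)cc3)C2)c1` gives 0%.

All three compounds share one core and differ only in the group on the aromatic carbon of the benzoyl ring. Compound 3 stands level with compound 2, the two together at the lowest of the three numbers, and its nearest neighbour is compound 2, with no change at the digits printed from compound 2 to compound 3 (within the scatter); its furthest is compound 1, with a number 2 percentage points lower from compound 1 to compound 3 (within the scatter). The third step, a number 2 percentage points lower from compound 1 to compound 2 (within the scatter), is also within the scatter, so the numbers show no movement at all across the three groups tried.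

Compound 4 `CCN(CC)S(=O)(=O)c1cccc(C(=O)N2CCCC(C(=O)Nc3ccc(Cl)cc3)C2)c1` carries the next variation at the same place, on an aromatic carbon of a six-membered aromatic ring of carbon only, meta to a large group: diethylsulfamoyl in place of methoxy on an aromatic carbon. The step that bears most on it is the one from a methylsulfonyl to a methoxy, a number 2 percentage points lower from compound 1 to compound 3 (within the scatter), since the incoming group is again a sulfur-bearing substituent; that step was within the scatter, as was every other step in the set. The expected step is therefore none beyond the scatter, a number 2 percentage points higher from compound 3 to compound 4 (within the scatter). Compound 4 is estimated at 2%, within -4% to 12%.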

Compound 4, a percentage reported as inhibition, at one concentration (the size of the read-out at that concentration, not a potency): 0%
Compound 4: middle estimate off by 2 percentage points, on the high side; the range from low to high includes it.
By their numbers in this assay, from the lowest: compounds 2, 3, 4 and 1 (each within the scatter of the next).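

The much bigger diethylsulfamoyl group, with 8 heavy atoms where methoxy has 2, leaves the picture at this place on the aromatic ring unchanged in this assay: the exchange gives no change at the digits printed from compound 3 to compound 4 (within the scatter). Set against the vinyl group, it gives no change at the digits printed from compound 2 to compound 4 (within the scatter), and diethylamino in place of methyl on the sulfonyl sulfur gives a number 2 percentage points lower from compound 1 to compound 4 (within the scatter), so this place now holds four different groups, including two sulfur-bearing ones, with every step among them inside the scatter. No supporting data are available to explain this absence of movement.

The compounds shown leave open whether any group at this place can lift the number clear of the scatter, for instance a carboxylic acid or a primary amine on the aromatic carbon. They also leave open whether the same flat result would hold with something other than the chlorine on the anilide ring, such as a methoxy or a nitrile, since all four compounds keep that part of the shared core unchanged.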